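This account rests on a few compounds, and the source may have more. Where it says the series, first, only, none or still open, it means among the compounds named here.

Of the compounds shown here, two sharing one core have been tested in a functional assay on HepG2 cells (Homo sapiens) for antiproliferative activity, read by XTT assay, with a stated time of 72 h; on this read-out higher numbers stand for weaker inhibition and lower numbers for stronger inhibition. Compound 1 `O=c1[nH]cnc2c1c(-c1ccoc1)cn2[C@@H]1O[C@H](CO)[C@@H](O)[C@H]1O` gives 12100 nM in this assay, a weak effect. Compound 2 `Cc1nc(N)c2c(-c3ccccc3)cn([C@@H]3O[C@H](CO)[C@@H](O)[C@H]3O)c2n1` is a different case. In this assay compound 2 is reported only as > 20000 nM, which is a limit of the assay rather than a number. Compound 2 therefore stands at the limit of > 20000 nM in this assay, at which 1 of the 2 values shown sits, and its true value is not pinned down; all that is known is that it inhibits growth weakly in this assay.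

Compound 3 `Cc1nc(N)c2c(-c3cccs3)cn([C@@H]3O[C@H](CO)[C@@H](O)[C@H]3O)c2n1` has not yet been measured. It differs from compound 2 in one place: thiophen-2-yl in place of phenyl on an aromatic carbon. No step between two measured compounds is shown for this kind of change, so there is nothing in the data to say how large an effect to expect in this assay or in which direction.

Compound 3 is therefore expected to stay weak, at an estimated 20000 nM with a likely range from 8000 nM to 60000 nM. The estimated step of a number no higher from compound 2 to compound 3 (the limit leaves the size open) is expected to be none beyond the usual scatter, and there is a fair chance that compound 3, like compound 2, is reported only as a limit.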

Compound 3, half-maximal inhibitory concentration: > 20000 nM
Compound 3 ended at the assay's limit; the forecaster's own chance of this, stated with the estimate: 55%; the middle value sits exactly at the limit.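

Compound 3 is reported in this assay only as > 20000 nM, which is a limit of the assay and not a number. Compound 2 also sits at a limit, so no step can be read between compound 2 and compound 3: the limit of > 20000 nM in this assay, at which 2 of the 3 values shown sit.

The compounds shown leave open the true values of compound 2 and compound 3, and whether thiophen-2-yl in place of phenyl changes growth inhibition at all.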